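Swapping a bromobenzyl arm for a methoxybenzyl arm

A few compounds are considered here, and "the series" means these few. Any claim that something is new, unique, unknown or untested is made for them only; others in the source may bear on it.

Three sulfonamides sharing one core have been tested so far. Compound 1 `O=S(=O)(NCCCCNCc1ccc(Br)cc1)c1cc(C(F)(F)F)cc(C(F)(F)F)c1` gives 3200 nM in a toxicity assay on MCF-10A cells (Homo sapiens) for inhibition, read by MTT assay, with a stated time of 72 h (on this read-out lower numbers stand for stronger inhibition of growth and higher numbers for weaker inhibition of growth), the lowest number of the three. Compound 2 `COc1ccc(CNCCCNS(=O)(=O)c2cc(C(F)(F)F)cc(C(F)(F)F)c2)cc1OC` gives 5300 nM, within the scatter of compound 1, while compound 3 `O=S(=O)(NCCCNCc1ccccc1Cl)c1cc(C(F)(F)F)cc(C(F)(F)F)c1` gives 11000 nM, clearly above both: a 3.4-fold higher number from compound 1 to compound 3 (0.54 log units; beyond the scatter) and a 2.1-fold higher number from compound 2 to compound 3 (0.32 log units; beyond the scatter).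

The new compound 4 `COc1ccccc1CNCCCNS(=O)(=O)c1cc(C(F)(F)F)cc(C(F)(F)F)c1` differs from compound 1 by one change: (2-methoxybenzyl)amino in place of ((4-bromobenzyl)amino)methyl on a saturated chain carbon, three bonds along the chain from a sulfonamide nitrogen. The step from compound 1 to compound 3 is the closest guide, since it removes the same group and brings in another benzyl amine carrying a single substituent on its ring; that step was a modest rise. The step from compound 2 to compound 3 shows a similar modest rise when a dimethoxy ring gives way to a ring bearing one substituent. For compound 4 a modest rise beyond the scatter is therefore expected, a 2.5-fold higher number from compound 1 to compound 4 (0.40 log units; beyond the scatter), so compound 4 is estimated at 8000 nM, with a likely range from 3500 nM to 18000 nM.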

Compound 4, concentration for 50% growth inhibition: 5500 nM
Beside the measured number, compound 4's estimate is 1.5-fold (0.16 log units) above it; the range from low to high includes it.
By their numbers in this assay, from the lowest: compounds 1, 2, 4 and 3 (each within the scatter of the next, the first and the last beyond it).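

Putting (2-methoxybenzyl)amino in place of ((4-bromobenzyl)amino)methyl at this chain carbon gives a step that does not separate the two compounds, a 1.7-fold higher number from compound 1 to compound 4 (0.24 log units; within the scatter), whereas the chlorine-bearing benzyl amine gave a 3.4-fold higher number from compound 1 to compound 3 (0.54 log units; beyond the scatter). In this assay, methoxy in place of chloro on the aromatic carbon gives a 2.0-fold lower number from compound 3 to compound 4 (0.30 log units; within the scatter), and 2-methoxyphenyl in place of 3,4-dimethoxyphenyl gives a 1.0-fold higher number from compound 2 to compound 4 (0.02 log units; within the scatter), so a single methoxy on the ring is enough to keep the number level with the dimethoxy ring. Nothing shown gives a measured reason for these numbers.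

The step from compound 1 changes the chain and the ring substituent together, so the compounds shown cannot assign its size to either one alone. Going by these compounds, how a hydroxy group or a nitrile on the ring, or a longer chain, would read here remains open.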